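This account rests on a few compounds, and the source may have more. Where it says the series, first, only, none or still open, it means among the compounds named here.

Working notes on the series, read in a functional assay on HepG2 cells (Homo sapiens) for inhibition, read by MTT assay, with a stated time of 120 h; a higher number here means a weaker inhibitor, a lower number a stronger inhibitor. Of the compounds shown here, two carry numbers so far. Compound 1 (`O=C(/C=C/c1ccc(NC(=O)Nc2ccc(Cl)c(C(F)(F)F)c2)cc1)NC1CCC1`) gives 7510 nM, the lower of the two numbers. Compound 2 (`CC(NC(=O)c1ccc(-c2ccc(NC(=O)Nc3cc(C(F)(F)F)ccc3Cl)cc2)cc1)c1ccccc1`) gives 18400 nM, and its gap to compound 1 lies beyond the usual scatter.

Still unmeasured is compound 3 (`O=C(CCc1ccc(NC(=O)Nc2ccc(Cl)c(C(F)(F)F)c2)cc1)NC1CCC1`), which is compound 1 with one change: 2-(cyclobutylcarbamoyl)ethyl in place of 2-(cyclobutylcarbamoyl)ethenyl on an aromatic carbon. In words, 2-(cyclobutylcarbamoyl)ethyl stands in place of 2-(cyclobutylcarbamoyl)ethenyl on an aromatic carbon, para to a large group, and the rest of the structure is kept.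

For the measured compounds named here, no measured pair shows what this change does, so the expectation rests only on compound 1 at 7510 nM. No step beyond the scatter is expected, with a slight lean towards a higher number. The estimated step is a 1.3-fold higher number from compound 1 to compound 3 (0.10 log units; within the scatter). For compound 3 the expected value is 9500 nM, with an estimated range of 4000 nM to 20000 nM.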

Compound 3, half-maximal inhibitory concentration: > 50000 nM
Compound 3 ended at the assay's limit; the forecaster's own chance of this, stated with the estimate: 10%; at least 5.2-fold (0.72 log units) between middle value and limit.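

In this assay, for the compounds shown here, the position on the aromatic carbon, para to a large group, proves sensitive to a change that the earlier compounds could not test, and the series gains its first single-place step: an at least 6.6-fold higher number from compound 1 to compound 3 (0.82 log units; beyond the scatter). Compound 3 gives > 50000 nM, which is a limit of the assay and not a number. The step is beyond the scatter, with 2-(cyclobutylcarbamoyl)ethyl and 2-(cyclobutylcarbamoyl)ethenyl differing only in the double bond of the ethenyl link, but its full size cannot be read because compound 3 stands at that limit: the limit of > 50000 nM in this assay, at which 1 of the 3 values shown sits.

Compound 2 differs from both other compounds in more than one place, so it cannot be read against this step, and the compounds shown do not tell whether the loss follows the double bond alone or also depends on the cyclobutyl amide. Open questions are how an ethynyl link or a longer chain would read at this position, and whether a carboxylic acid or an amine in place of the cyclobutyl amide would behave the same way on the ethenyl and ethyl links.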